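Amide aryl swap on the shared core: compound 4

This account rests on a few compounds, and the source may have more. Where it says the series, first, only, none or still open, it means among the compounds named here.

In an ADME assay on MRC5 cells (Homo sapiens) for inhibition, with a stated time of 72 h (on this read-out higher numbers stand for an effect only at larger amounts of compound and lower numbers for an effect already at smaller amounts), compound 1 `CO[C@H]1CC[C@H](NC(=O)c2n[nH]cc2NC(=O)c2cnc3ccccn23)CC1` gives 5900 nM, compound 2 `CO[C@H]1CC[C@H](NC(=O)c2n[nH]cc2NC(=O)c2cc3ccccn3n2)CC1` gives 1000 nM, and compound 3 `CO[C@H]1CC[C@H](NC(=O)c2n[nH]cc2NC(=O)c2cc3ccccc3o2)CC1` gives 800 nM. Compound 3 holds the lowest of the three numbers: the step of a 1.3-fold lower number from compound 2 to compound 3 (0.10 log units; within the scatter) sits within the scatter, while a 7.4-fold lower number from compound 1 to compound 3 (0.87 log units; beyond the scatter) and a 5.9-fold lower number from compound 1 to compound 2 (0.77 log units; beyond the scatter) are modest. Compound 4 `CO[C@H]1CC[C@H](NC(=O)c2n[nH]cc2NC(=O)c2cc(Cl)cc(Cl)c2)CC1` brings (3,5-dichlorophenyl in place of 1-benzofuran-2-yl on a carbonyl carbon). All measured steps swap one bicyclic group for another on that carbonyl carbon; none introduces a single six-membered ring of carbon only, so they bear only loosely on this change. Their spread suggests a step no larger than modest in this assay, more likely toward a higher number. Compound 4 is therefore expected near 1500 nM, between 500 nM and 5000 nM, a step of a 1.9-fold higher number from compound 3 to compound 4 (0.27 log units; within the scatter).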

Compound 4, half-maximal effective concentration: 13000 nM
For compound 4 the middle estimate is 8.7-fold (0.94 log units) below the measured one; measured number outside the range, above it.
By their numbers in this assay, from the lowest: compounds 3 and 2 (each within the scatter of the next); then compound 1; then compound 4.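

In this assay the carbonyl carbon tolerates swaps among bicyclic groups better than the move to a single ring: 3,5-dichlorophenyl gives a 16-fold higher number from compound 3 to compound 4 (1.21 log units; beyond the scatter) and a 13-fold higher number from compound 2 to compound 4 (1.11 log units; beyond the scatter) and both steps are large. The step of a 2.2-fold higher number from compound 1 to compound 4 (0.34 log units; beyond the scatter) is only modest but lies beyond the scatter, so all three bicyclic groups shown sit at lower numbers than 3,5-dichlorophenyl. Nothing at hand explains this shift.

As far as these compounds go, whether the loss follows the single ring or the two chlorine atoms stays open. Unsubstituted phenyl would separate the two.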